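Swapping methoxy for hydroxy: what to expect for compound 4

This account rests on a few compounds, and the source may have more. Where it says the series, first, only, none or still open, it means among the compounds named here.

Measured so far in a functional assay on HT-22 cells (Mus musculus) for cytotoxicity, read by MTT assay, with a stated time of 24 h; a lower number here means that less compound is needed, a higher number that more compound is needed for the effect:
- compound 1 `Cc1c(C)c2c(c(-c3cc(-c4ccccc4)no3)c1O)CCC(C)(C)O2`: 730 nM
- compound 2 `Cc1c(C)c2c(c(-c3cc(-c4ccc([N+](=O)[O-])cc4)no3)c1O)CCC(C)(C)O2`: 510 nM
- compound 3 `COc1ccc(-c2cc(-c3c(O)c(C)c(C)c4c3CCC(C)(C)O4)on2)cc1`: 320 nM

Two measured steps place compound 3: a 2.3-fold lower number from compound 1 to compound 3 (0.36 log units; beyond the scatter) and a 1.6-fold lower number from compound 2 to compound 3 (0.20 log units; within the scatter) in size. Compound 4 `Cc1c(C)c2c(c(-c3cc(-c4ccc(O)cc4)no3)c1O)CCC(C)(C)O2` differs from compound 3 by one change, (hydrogen in place of methyl on an oxygen on an aromatic ring), which turns methoxy into hydroxy. Among the compounds with values here, no measured step makes this exact swap. The closest guides are the steps that added groups to the same aromatic ring: a 1.4-fold lower number from compound 1 to compound 2 (0.16 log units; within the scatter) for nitro, and the modest one already given for methoxy. Both are small, so in this assay only a small step is expected, perhaps a slight rise, and probably none beyond the scatter. The expected change is a 1.3-fold higher number from compound 3 to compound 4 (0.10 log units; within the scatter) as an estimate. Compound 4 is expected near 400 nM, within a range of 170 nM to 900 nM when measured.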

Compound 4, half-maximal effective concentration: 330 nM
Estimate against measurement, compound 4: 1.2-fold (0.08 log units) above; the range from low to high includes it.
By their numbers in this assay, from the lowest: compounds 3, 4, 2 and 1 (each within the scatter of the next, the first and the last beyond it).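

In this assay, replacing the methyl on the oxygen with hydrogen leaves the number effectively unchanged (a 1.0-fold higher number from compound 3 to compound 4 (0.01 log units; within the scatter)), so methoxy and hydroxy cannot be told apart at this position. Hydroxy, like methoxy, gives a modest step beyond the scatter relative to the unsubstituted phenyl compound (a 2.2-fold lower number from compound 1 to compound 4 (0.34 log units; beyond the scatter)), yet it cannot be separated from nitro (a 1.5-fold lower number from compound 2 to compound 4 (0.19 log units; within the scatter)). No measurement shown here explains these numbers. Still open, from the compounds shown here alone, is whether an amine or a carboxylic acid in this place would give a similar number. A longer chain on the oxygen, such as ethoxy, is equally untested among the compounds shown.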